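A Third Hydroxy Group on the Shared Core

The compounds below may be only part of what the source reports. "The series", "measured", "known", "first", "only" and "open" are said of these compounds alone.

Two imines built on the same benzyloxy-bearing core have been measured. Compound 1 `Oc1ccc(/C=N/c2ccc(OCc3ccccc3)cc2)c(O)c1` carries a 2,4-dihydroxyphenyl group on the carbon that is double-bonded to nitrogen; in an assay on isolated protein for inhibition of Amine oxidase [flavin-containing] B (Homo sapiens), read by fluorescence and Amplex Red, with stated times of 15 min and 20 min (on this read-out higher numbers stand for weaker inhibition and lower numbers for stronger inhibition), compound 1 gives 6780 nM. Compound 2 `Oc1cccc(/C=N/c2ccc(OCc3ccccc3)cc2)c1O` carries a 2,3-dihydroxyphenyl group there instead, and in this assay compound 2 gives 6870 nM. The step of a 1.0-fold higher number from compound 1 to compound 2 (0.01 log units; within the scatter) shows that moving one hydroxy group left the number where it was, so the two values stand together and no order between them can be read.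

Compound 3 `Oc1ccc(/C=N/c2ccc(OCc3ccccc3)cc2)c(O)c1O` differs from compound 2 by hydroxy in place of hydrogen on an aromatic carbon. Among the measured compounds shown here, no measured step adds a hydroxy group; the only step available concerns a hydroxy group that kept its number when it moved. The expectation for compound 3 is therefore a step of a 1.1-fold lower number from compound 2 to compound 3 (0.06 log units; within the scatter), not beyond the scatter, in either direction. Compound 3 is estimated at 6000 nM in this assay, within 2500 nM and 15000 nM.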

Compound 3, half-maximal inhibitory concentration: 1730 nM
The estimate for compound 3 lay 3.5-fold (0.54 log units) above the measured number; the whole stated range lies above it.
By their numbers in this assay, from the lowest: compound 3; then compounds 1 and 2 (each within the scatter of the next).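

Moving a hydroxy group left the number unchanged in this assay, but adding a third one gives a 4.0-fold lower number from compound 2 to compound 3 (0.60 log units; beyond the scatter) and a 3.9-fold lower number from compound 1 to compound 3 (0.59 log units; beyond the scatter) on the same read-out. The earlier pair spoke only to where two hydroxy groups sit, whereas this result shows that the number of hydroxy groups on this six-membered aromatic ring can matter: on the step from compound 2, the new group stands ortho to a hydroxy group, meta to a hydroxy group and para to a large group, and inhibition is stronger. Nothing shown accounts for this gain.

The compounds shown leave open whether a methoxy group, an amine or a fluorine atom at this place would go the same way as hydroxy. They also leave open whether the gain would hold if a shorter chain took the place of the benzyloxy group on the core.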